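Mirror-image pair in a cytotoxicity readout

The source may report more compounds than this note shows. Statements on the series, on what has been measured and on what is new or still open speak of the compounds shown alone.

Compounds measured so far:
compound 1, `CC[C@@H](CCn1cncn1)c1ccc(C)cc1`: 79.4 ug/mL
compound 2, `COc1ccc([C@H](CCn2cncn2)Cc2ccccc2)cc1`: 66 ug/mL
compound 3, `Cc1ccc([C@@H](CCn2cncn2)Cc2ccccc2)cc1`: 109 ug/mL

Of the compounds shown here, three have been tested in an ADME assay on RD cells (Homo sapiens) for cytotoxicity, read by MTT assay, with a stated time of 3 days; a higher number here means that more compound is tolerated, a lower number that less compound is tolerated. Compound 1 gives 79.4 ug/mL, compound 2 gives 66 ug/mL, and compound 3 gives 109 ug/mL. Of the three numbers, that of compound 3 is the highest as written, but its gap to compound 1 and its gap to compound 2 both fall within the usual scatter of this assay, so the three compounds cannot be told apart on these data.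

The next compound, compound 4, has the structure `Cc1ccc([C@H](CCn2cncn2)Cc2ccccc2)cc1`. The difference from compound 3 is the two compounds have the same atoms and bonds and differ only in configuration as drawn: 1 of 1 stereo elements differ; a stereocentre at a saturated chain carbon is drawn R in compound 3 and S in compound 4. Going by the values given here, no pair of measured compounds differs in this way, so there is no measured step to lean on. With nothing in the series pointing toward a dependence on configuration, and with all three measured values within the scatter of one another, the expected step from compound 3 to compound 4 in this assay is none beyond the scatter. The estimate therefore implies a step of a 1.1-fold lower number from compound 3 to compound 4 (0.06 log units; within the scatter) that stays within the scatter. Compound 4 is expected to give 95 ug/mL, with a range from 50 ug/mL to 180 ug/mL.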

Compound 4, half-maximal cytotoxic concentration: 117 ug/mL
Compound 4: middle estimate off by 1.2-fold (0.09 log units), on the low side, within the range that was stated.
By their numbers in this assay, from the lowest: compounds 2, 1, 3 and 4 (each within the scatter of the next).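

Going by these compounds alone, a step of a 1.1-fold higher number from compound 3 to compound 4 (0.03 log units; within the scatter) is the first measured comparison of configuration at this saturated chain carbon in this assay, and it shows that drawing the stereocentre S in place of R makes no difference this assay can resolve. Compound 4 also links to the other two compounds, with a 1.8-fold higher number from compound 2 to compound 4 (0.25 log units; within the scatter) for methyl in place of methoxy on an aromatic carbon and a 1.5-fold higher number from compound 1 to compound 4 (0.17 log units; within the scatter) for phenyl in place of methyl on a saturated chain carbon, two bonds along the chain from an aromatic carbon, so neither of these single changes separates the compounds either. The comparison of the mirror-image pair can be read as one of configuration alone, since nothing else separates them: the fact that compounds 3 and 4 differ only in the configuration as drawn.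

The compounds shown leave open whether configuration is equally silent when methoxy takes the place of methyl on the aromatic carbon. They also leave open whether an amine or a carboxylic acid on that aromatic carbon, or a longer chain in place of the phenyl, would give a step beyond the scatter.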